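The source may hold more compounds than are shown below. What is called first, only, known or untested is meant among the compounds shown, and "the series" means these compounds.

Compound 1 `Cn1c2c(c3ccccc3c1=O)CCOc1ccccc1-2` is the parent of this set. In an assay on isolated protein for inhibition of DNA topoisomerase 1 (Homo sapiens), tested at 100 uM (a higher number here means more inhibition at the concentration tested (going by the name of the read-out), a lower number less inhibition), compound 1 gives "not active" (no number reported), so no number stands for it, only the note that the read-out did not register. Compound 2 `Cc1ccc2c3c(n(C)c(=O)c2c1)-c1ccccc1OCC3`, which carries a methyl on the shared core, gives 11.9% in this assay, which is a low inhibition for the series as a whole. Compound 3 `COc1ccc(Cn2c3c(c4ccccc4c2=O)CCOc2ccccc2-3)cc1` differs from compound 1 by 4-methoxyphenyl in place of hydrogen on a saturated chain carbon bound to an aromatic nitrogen. Within the data shown here, no measured pair shows this change, so its effect in this assay cannot be read from the data; the step from compound 1 to compound 3 is expected to be small and, if anything, upward, most likely staying within the usual scatter of the read-out. For compound 3 the inhibition in this assay is therefore estimated at 15%, with a plausible range from 0% to 40%, and it may again be reported only as not active.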

Compound 3, a percentage reported as inhibition, at one concentration (the size of the read-out at that concentration, not a potency): 94.5%
Beside the measured number, compound 3's estimate is 79.5 percentage points below it, and the stated range ends below it.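

Among these compounds, compound 1 stands only as "not active" (no number reported) and no step to compound 3 can be read from it. The compounds shown leave open how much inhibition goes with 4-methoxybenzyl in place of methyl on the shared core. No measurement bearing on a cause is available.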